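Nitrophenyl for pyridyl on a tetrahydropyran scaffold

The source may hold more compounds than are shown below. What is called first, only, known or untested is meant among the compounds shown, and "the series" means these compounds.

Measured compounds:
compound 1 `O[C@@H](c1ccccc1)[C@H]1CO[C@H](c2ccccc2)[C@@H](C/C=C/c2ccccn2)C1` — 36400 nM
compound 2 `COc1ccc(/C=C/C[C@@H]2C[C@H]([C@H](O)c3ccc(OC)c(OC)c3)CO[C@H]2c2ccc(OC)c(OC)c2)cc1OC` — "not determined" (no result reported)

Among the measured compounds shown here, compound 1 is the only compound with a number in a functional assay on HL-60 cells (Homo sapiens) for cytotoxicity, read by WST assay, with a stated time of 48 h; on this read-out higher numbers stand for weaker inhibition and lower numbers for stronger inhibition; in this assay compound 1 gives 36400 nM, and compound 2 is recorded there as "not determined" (no result reported), so no comparison between the two is possible. Compound 3 `O=[N+]([O-])c1ccccc1/C=C/C[C@H]1C[C@@H]([C@@H](O)c2ccccc2)CO[C@@H]1c1ccccc1` differs from compound 1 by 2-nitrophenyl in place of pyridin-2-yl on a double-bonded chain carbon bound to a double-bonded chain carbon. For the measured compounds named here, no step between measured compounds is known for this change. A modest shift toward stronger inhibition is expected, with the step from compound 1 to compound 3 estimated at a 1.5-fold lower number from compound 1 to compound 3 (0.16 log units; within the scatter). Compound 3 is therefore expected to give 25000 nM, within a range of 6000 nM to 100000 nM.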

Compound 3, half-maximal inhibitory concentration: 7250 nM
Compound 3: the middle estimate sits 3.4-fold (0.54 log units) above what was measured; the measured number falls inside the stated range.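

In this assay this position proves responsive: 2-nitrophenyl in place of pyridin-2-yl on a double-bonded chain carbon bound to a double-bonded chain carbon gives a 5.0-fold lower number from compound 1 to compound 3 (0.70 log units; beyond the scatter) with the rest of the molecule unchanged. Nothing available explains this shift.

The exchange alters both the ring atoms and the nitro group at once, so the compounds shown do not tell which of the two carries the shift. A plain phenyl at this place would separate them.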